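Propyl to butyl on the shared core

This account rests on a few compounds, and the source may have more. Where it says the series, first, only, none or still open, it means among the compounds named here.

All numbers below come from a functional assay on HCT-116 cells (Homo sapiens) for inhibition, read by luminescence and resazurin assay, with a stated time of 3 days; a higher number here means a weaker inhibitor, a lower number a stronger inhibitor.

compound 1, `CNc1nc(NCc2ccc(NC(=O)c3ccc(F)cc3)cc2Cl)c2ccccc2n1`: 2000 nM
compound 2, `CCNc1nc(NCc2ccc(NC(=O)c3ccc(F)cc3)cc2Cl)c2ccccc2n1`: 1500 nM
compound 3, `CCCNc1nc(NCc2ccc(C(=O)Nc3ccc(F)cc3)cc2)c2ccccc2n1`: 1500 nM

Compound 4, `CCCCNc1nc(NCc2ccc(C(=O)Nc3ccc(F)cc3)cc2)c2ccccc2n1`, has not yet been measured in this assay.

Compound 2 differs from compound 1 by methyl in place of hydrogen on a saturated chain carbon bound to a nitrogen on an aromatic ring. The step was a 1.3-fold lower number from compound 1 to compound 2 (0.12 log units; within the scatter). Compound 4 differs from compound 3 by methyl in place of hydrogen on a saturated chain carbon, three bonds along the chain from a nitrogen on an aromatic ring. The place is not identical in the two pairs: in the first the carbon is bound to a nitrogen on an aromatic ring, in the second it is three bonds along the chain from a nitrogen on an aromatic ring, so this is the same kind of change, not the same change. Compound 1 and compound 3 differ in more than one place; the difference between the two cores is not broken down here. In this assay compound 3 and compound 2 stand level at the digits recorded, and compound 1 lies within the scatter of both.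

Within the data shown here, the expectation for compound 4 rests on a 1.3-fold lower number from compound 1 to compound 2 (0.12 log units; within the scatter), the only measured instance of this kind of change, which stayed within the scatter; the chain is propyl in compound 3 and butyl in compound 4. The expected step is a 1.2-fold lower number from compound 3 to compound 4 (0.06 log units; within the scatter). Compound 4 is estimated at 1300 nM in this assay, with the likely range running from 600 nM to 3000 nM.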

Compound 4, half-maximal inhibitory concentration: 1400 nM
Compound 4: the middle estimate sits 1.1-fold (0.03 log units) below what was measured; the measured number falls inside the stated range.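

In this assay, methyl in place of hydrogen at the end of the propyl chain gives a 1.1-fold lower number from compound 3 to compound 4 (0.03 log units; within the scatter), so compound 3 and compound 4 cannot be told apart. Set beside the earlier step, the same kind of change reads alike on the two cores: the same change on two cores in this assay, a 1.3-fold lower number (0.12 log units; within the scatter) from compound 1 to compound 2 and a 1.1-fold lower number (0.03 log units; within the scatter) from compound 3 to compound 4, 1.2-fold (0.09 log units) apart, within the scatter of two such steps

This shows that the change has so far been tolerated on both cores, with neither step large enough to separate from repeated-measurement noise, and no sign of a core-dependent difference between them. It does not show a real gain on either core, nor that a measurable effect would carry from one core to the other, since two steps within the scatter offer no such effect to follow, and the carbon that changes lies at a different place along the chain in each pair, one bound to a nitrogen on an aromatic ring and the other three bonds along.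

Open in these compounds is whether a longer chain such as hexyl, or a branched chain such as isopropyl, would give a step beyond the scatter on either core. Also open, as far as these compounds go, is how a chain ending in an amine or a carboxylic acid would read in this assay.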